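The source may hold more compounds than are shown below. What is called first, only, known or untested is meant among the compounds shown, and "the series" means these compounds.

In a functional assay on MCF7 cells (Homo sapiens) for antiproliferative activity, read by MTT assay, with a stated time of 72 h (on this read-out lower numbers stand for stronger inhibition and higher numbers for weaker inhibition), three compounds sharing one core have been measured: compound 1 `CC1=CC[C@H]2[C@H](CC[C@]2(C)O)C(C)(C)[C@@H]1CC[C@H]1[C@]2(C)CC[C@H](OC(=O)c3ccccc3)C(C)(C)O[C@H]2CC[C@@]1(C)O` gives 21000 nM, compound 2 `CC1=CC[C@H]2[C@H](CC[C@]2(C)O)C(C)(C)[C@@H]1CC[C@H]1[C@]2(C)CC[C@H](OC(=O)NCc3ccccc3)C(C)(C)O[C@H]2CC[C@@]1(C)O` gives 24500 nM, and compound 3 `CC1=CC[C@H]2[C@H](CC[C@]2(C)O)C(C)(C)[C@@H]1CC[C@H]1[C@]2(C)CC[C@H](OC(=O)c3ccc([N+](=O)[O-])cc3)C(C)(C)O[C@H]2CC[C@@]1(C)O` gives 21600 nM. Compound 3 therefore stands level with the other two. Compound 4 `CC1=CC[C@H]2[C@H](CC[C@]2(C)O)C(C)(C)[C@@H]1CC[C@H]1[C@]2(C)CC[C@H](OC(=O)c3ccccc3[N+](=O)[O-])C(C)(C)O[C@H]2CC[C@@]1(C)O` differs from it by one change, 2-nitrophenyl in place of 4-nitrophenyl on a carbonyl carbon. Among the compounds with values here, no measured step makes this exact change, so the evidence is indirect. Adding the nitro group gave a 1.0-fold higher number from compound 1 to compound 3 (0.01 log units; within the scatter), while replacing the group on the carbonyl carbon gave a 1.2-fold higher number from compound 1 to compound 2 (0.07 log units; within the scatter) and a 1.1-fold lower number from compound 2 to compound 3 (0.05 log units; within the scatter). With all of these flat, no step beyond the scatter is expected in this assay, in either direction. The expected step is a 1.0-fold higher number from compound 3 to compound 4 (0.01 log units; within the scatter). The estimate for compound 4 is 22000 nM, with an expected range of 12000 nM to 40000 nM.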

Compound 4, half-maximal inhibitory concentration: 5200 nM
Beside the measured number, compound 4's estimate is 4.2-fold (0.63 log units) above it; measured number outside the range, below it.
By their numbers in this assay, from the lowest: compound 4; then compounds 1, 3 and 2 (each within the scatter of the next).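

In this assay, within the data shown here, 2-nitrophenyl in place of 4-nitrophenyl gives a 4.2-fold lower number from compound 3 to compound 4 (0.62 log units; beyond the scatter) and is the first change on this carbonyl carbon to go beyond the scatter, so where the nitro group sits on the ring matters here. The same group gives a 4.0-fold lower number from compound 1 to compound 4 (0.61 log units; beyond the scatter) against the plain phenyl and a 4.7-fold lower number from compound 2 to compound 4 (0.67 log units; beyond the scatter) against benzylamino, whereas 4-nitrophenyl stayed level with both. Nothing measured here accounts for this difference. Going by these compounds, it remains open how 3-nitrophenyl would compare with these two groups. On these data alone, it is also open whether 2-methoxyphenyl or 2-aminophenyl would match 2-nitrophenyl.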